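Swapping Difluoro for Chloro on the Benzamide Ring

The source may report more compounds than this note shows. Statements on the series, on what has been measured and on what is new or still open speak of the compounds shown alone.

Three compounds share a core and differ only in the ring attached to the carbonyl carbon. Compound 1 `CC(C)S(=O)(=O)n1c(N)nc2ccc(NC(=O)c3ccccc3)cc21` carries a plain phenyl there, and in an ADME assay on HepG2 2.2.15 cells (Homo sapiens) for cytotoxicity, read by MTT assay, with a stated time of 6 h (a lower number here means that less compound is tolerated, a higher number that more compound is tolerated), compound 1 gives only a limit, > 500000 nM. Compound 2 `CC(C)S(=O)(=O)n1c(N)nc2ccc(NC(=O)c3ccccc3F)cc21` bears a single fluoro, and in this assay compound 2 gives 48000 nM; the step of an at least 10-fold lower number from compound 1 to compound 2 (1.01 log units; beyond the scatter) is large. Compound 3 `CC(C)S(=O)(=O)n1c(N)nc2ccc(NC(=O)c3c(F)cccc3F)cc21` carries a 2,6-difluorophenyl, and in this assay compound 3 gives 192000 nM, so that a 4.0-fold higher number from compound 2 to compound 3 (0.60 log units; beyond the scatter) and an at least 2.6-fold lower number from compound 1 to compound 3 (0.41 log units; beyond the scatter). Among the two measured numbers, compound 3 stands highest, with compound 2 as its nearest neighbour.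

Compound 4 `CC(C)S(=O)(=O)n1c(N)nc2ccc(NC(=O)c3ccccc3Cl)cc21` differs from compound 3 by 2-chlorophenyl in place of 2,6-difluorophenyl on a carbonyl carbon. Among the compounds with values here, of the measured steps, a 4.0-fold higher number from compound 2 to compound 3 (0.60 log units; beyond the scatter) bears most on this change, since the loss of one fluoro runs that step backwards; the chloro in place of fluoro has no measured counterpart here. Compound 4 is therefore expected to give a modestly lower number, a 3.5-fold lower number from compound 3 to compound 4 (0.54 log units; beyond the scatter), estimated at 55000 nM with a range from 15000 nM to 200000 nM.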

Compound 4, half-maximal cytotoxic concentration: 88000 nM
Compound 4: the middle estimate sits 1.6-fold (0.20 log units) below what was measured, within the range that was stated.
By their numbers in this assay, from the lowest: compounds 2 and 4 (each within the scatter of the next); then compound 3. At a limit, above all of these: compound 1.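

In this assay the step is a 1.8-fold higher number from compound 2 to compound 4 (0.26 log units; within the scatter), so chloro in place of fluoro on an aromatic carbon does not separate these two compounds, and the two rings carrying one halogen read alike. The 2-chlorophenyl does not match the 2,6-difluorophenyl, the step being a 2.2-fold lower number from compound 3 to compound 4 (0.34 log units; beyond the scatter), which leaves compound 3 apart from both compounds with a single halogen, while the comparison with the unsubstituted phenyl gives an at least 5.6-fold lower number from compound 1 to compound 4 (0.75 log units; beyond the scatter). That comparison rests on a limit, not a number: the limit of > 500000 nM in this assay, at which 1 of the 4 values shown sits.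

The compounds shown leave open whether a second chloro would raise the number as the second fluoro did. They also leave open whether a methoxy or an amine in place of the halogen would read like chloro and fluoro.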